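The source may report more compounds than this note shows. Statements on the series, on what has been measured and on what is new or still open speak of the compounds shown alone.

Values in a functional assay on the whole organism (strain Wistar) for inhibition, with Rattus norvegicus as the target, read by paw edema, with stated times of 60 min and 1 h, at a dose of 100 mg/kg by the oral route (on this read-out higher numbers stand for more inhibition at the one dose given (going by the name of the read-out) and lower numbers for less inhibition), for the three measured members of the series:

compound 1, `COc1cc2c(cc1OC)C(CC(=O)NC(C)C)CC2`: 31.3%
compound 2, `CCCCCNC(=O)CC1CCc2cc(OC)c(OC)cc21`: 34.4%
compound 3, `COc1cc2c(cc1OC)C(CC(=O)N1CCCC1)CC2`: 4.69%

Compound 3 holds the lowest number of the three. The step of a number 26.6 percentage points lower from compound 1 to compound 3 (beyond the scatter) and the step of a number 29.7 percentage points lower from compound 2 to compound 3 (beyond the scatter) both lie beyond the scatter, whereas a number 3.1 percentage points higher from compound 1 to compound 2 (within the scatter) stays within it, so the two open-chain amides cannot be ordered against each other on these numbers.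

Compound 4, `COc1cc2c(cc1OC)C(CC(=O)NCCO)CC2`, is the next member to be read in this assay. Against compound 3 the change is (2-hydroxyethyl)amino in place of pyrrolidin-1-yl on a carbonyl carbon. Within the data shown here, the steps that bear on it are those into compound 3, each of which carried a pyrrolidin-1-yl in place of an open-chain amino group on the carbonyl carbon and lowered the read-out by a modest amount. The change to compound 4 runs in the opposite sense, from pyrrolidin-1-yl back to an open-chain amino group, so a rise beyond the scatter is expected, of about a number 25.3 percentage points higher from compound 3 to compound 4 (beyond the scatter). Among the measured compounds shown here, no measured compound carries a (2-hydroxyethyl)amino group, so the size is uncertain. For compound 4 the estimate in this assay is 30%, within a range of 15% to 45%.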

Compound 4, a percentage reported as inhibition, in the whole organism at one dose (the size of the read-out at that dose, not a potency): 0%
Compound 4: the middle estimate sits 30 percentage points above what was measured, and the stated range ends above it.
By their numbers in this assay, from the lowest: compounds 4 and 3 (each within the scatter of the next); then compounds 1 and 2 (each within the scatter of the next).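

In this assay, an open-chain amino group on the carbonyl carbon does not by itself restore the read-out: (2-hydroxyethyl)amino in place of pyrrolidin-1-yl gives a number 4.7 percentage points lower from compound 3 to compound 4 (within the scatter), so the two groups cannot be told apart on these numbers. The open-chain amides are also no longer uniform at this position: 2-hydroxyethyl in place of isopropyl gives a number 31.3 percentage points lower from compound 1 to compound 4 (beyond the scatter), and hydroxy in place of propyl on a saturated chain carbon, two bonds along the chain from an amide-type nitrogen, gives a number 34.4 percentage points lower from compound 2 to compound 4 (beyond the scatter), whereas pentyl in place of isopropyl gave only a number 3.1 percentage points higher from compound 1 to compound 2 (within the scatter). No information is available to explain this difference among the open-chain amides.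

The compounds shown leave open whether the fall from compound 1 and compound 2 goes with the hydroxy group or with the two-carbon chain, a question that an ethylamino or a 2-methoxyethylamino group on the carbonyl carbon would separate. Going by these compounds, it also remains open whether other cyclic amino groups, such as piperidin-1-yl or morpholin-4-yl, would read like pyrrolidin-1-yl in this assay.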